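From a methyl pyrazole to an ethyl pyrazole

This account rests on a few compounds, and the source may have more. Where it says the series, first, only, none or still open, it means among the compounds named here.

Three compounds share one core and differ in the group on an aromatic carbon of its five-membered aromatic ring with 1 nitrogen and 1 oxygen. In a functional assay on A2780 cells (Homo sapiens) for inhibition (on this read-out higher numbers stand for weaker inhibition and lower numbers for stronger inhibition), compound 1 `CCNC(=O)c1noc(-c2cc(C(C)C)c(O)cc2O)c1-c1cc(CNC)no1` has no usable result, its entry reading "not determined" (no result reported). Compound 2 `CCNCc1cc(-c2c(C(=O)NCC)noc2-c2cc(C(C)C)c(O)cc2O)on1` gives 45 nM, and compound 3 `CCNC(=O)c1noc(-c2cc(C(C)C)c(O)cc2O)c1-c1ccn(C)n1` gives 12 nM. Compound 3 therefore holds the lower of the two numbers available, meaning the stronger inhibition.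

Compound 4 `CCNC(=O)c1noc(-c2cc(C(C)C)c(O)cc2O)c1-c1cnn(CC)c1` has not been measured yet. Its change from compound 3 is 1-ethyl-1H-pyrazol-4-yl in place of 1-methyl-1H-pyrazol-3-yl on an aromatic carbon: 1-ethyl-1H-pyrazol-4-yl takes the place of 1-methyl-1H-pyrazol-3-yl.

Going by the values given here, only one measured step bears on this, a 3.8-fold lower number from compound 2 to compound 3 (0.57 log units; beyond the scatter), a modest change on replacing 3-((ethylamino)methyl)-1,2-oxazol-5-yl with 1-methyl-1H-pyrazol-3-yl. That swap exchanged one ring type for another, whereas the new change keeps a pyrazole, so a smaller shift seems likely. Among the compounds with values here, no measured pair isolates either the new attachment point or the ethyl group, so the direction stays open. The expected move is a 1.3-fold higher number from compound 3 to compound 4 (0.10 log units; within the scatter), which would stay within the usual scatter. In this assay the estimate for compound 4 is 15 nM, with an expected range of 5 nM to 50 nM.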

Compound 4, half-maximal inhibitory concentration: 30 nM
For compound 4 the middle estimate is 2.0-fold (0.30 log units) below the measured one, and the stated range covers the measured number.
By their numbers in this assay, from the lowest: compound 3; then compounds 4 and 2 (each within the scatter of the next).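

In this assay, the move to 1-ethyl-1H-pyrazol-4-yl gives a 2.5-fold higher number from compound 3 to compound 4 (0.40 log units; beyond the scatter), so keeping a pyrazole on this aromatic carbon does not by itself preserve the number of compound 3. The second step, a 1.5-fold lower number from compound 2 to compound 4 (0.18 log units; within the scatter), lies within the scatter, so compound 4 with its pyrazole cannot be told apart from compound 2 with its 3-((ethylamino)methyl)-1,2-oxazol-5-yl group, which shows that having a pyrazole here is not enough to separate a compound from compound 2, as compound 3 was separated. Nothing measured here gives a reason for these differences.

On these data alone, compound 4 differs from compound 3 in both the ring's attachment point and the alkyl group on the pyrazole, so the share of each in the step remains open. A 1-methyl-1H-pyrazol-4-yl group would pair the attachment point of compound 4 with the methyl of compound 3 and could pull the two apart, while a longer chain such as propyl on the pyrazole would show whether the trend in size continues at all.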